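The source may hold more compounds than are shown below. What is called first, only, known or untested is meant among the compounds shown, and "the series" means these compounds.

Measured so far in an assay on BTI-TN-5B1-4 cells for inhibition of Amine oxidase [flavin-containing] B (Homo sapiens), read by fluorescence and Amplex Red, using microsomes, with a stated time of 30 min; a higher number here means a weaker inhibitor, a lower number a stronger inhibitor: compound 1 `C#CCOc1ccc(-c2cc(-c3ccc(OCC#C)c(OC)c3)nc(C)n2)cc1` gives 21100 nM; compound 2 `C#CCOc1ccc(-c2cc(-c3ccc(OCC#C)c(OCC)c3)nc(-c3ccccc3)n2)cc1` gives 29000 nM.

Compound 2 has the highest of the two numbers. Its nearest neighbour is compound 1, whose value lies within the scatter of that of compound 2, so the two are not distinguished. Among the measured compounds shown here, no step between measured compounds that differ in a single place is available.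

Compound 3 `C#CCOc1ccc(-c2cc(-c3ccc(OCC#C)c(OCC)c3)nc(C)n2)cc1` differs from compound 2 by methyl in place of phenyl on an aromatic carbon. With both measured compounds weak and close together, no step beyond the scatter is expected in this assay. The expected step is a 1.3-fold lower number from compound 2 to compound 3 (0.10 log units; within the scatter). Compound 3 is estimated at 23000 nM, with a range of 8000 nM to 65000 nM.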

Compound 3, half-maximal inhibitory concentration: 11000 nM
Estimate against measurement, compound 3: 2.1-fold (0.32 log units) above, within the range that was stated.
By their numbers in this assay, from the lowest: compounds 3, 1 and 2 (each within the scatter of the next, the first and the last beyond it).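

In this assay, among the compounds shown here, the aromatic carbon between two ring nitrogen atoms proves sensitive to its substituent: methyl in place of phenyl gives a 2.6-fold lower number from compound 2 to compound 3 (0.42 log units; beyond the scatter), the first single-place step beyond the scatter, though only a modest one. Methyl in place of hydrogen on the saturated chain carbon bound to an oxygen on an aromatic ring gives a 1.9-fold lower number from compound 1 to compound 3 (0.28 log units; within the scatter), so that change is not resolved. Nothing available here bears on the reason for the phenyl-to-methyl step. Still open, going by these compounds, is how hydrogen, an amine or a longer chain would read at this position.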